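Compound 3 to a 2-hydroxyphenyl analogue

A few compounds are considered here, and "the series" means these few. Any claim that something is new, unique, unknown or untested is made for them only; others in the source may bear on it.

In a functional assay on HepG2 cells (Homo sapiens) for antiproliferative activity, read by MTT assay, with a stated time of 48 h (a higher number here means a weaker inhibitor, a lower number a stronger inhibitor), compound 1 (`CC(=O)N1N=C(c2ccc3ccccc3c2)OC1c1ccccc1Br`) gives 3.98 ug/mL, compound 2 (`CC(=O)N1N=C(c2ccc3ccccc3c2)OC1c1cccc(Br)c1`) gives 1.68 ug/mL and compound 3 (`CC(=O)N1N=C(c2ccc3ccccc3c2)OC1c1cccc(F)c1`) gives 1.86 ug/mL. Compound 3 belongs to the lower pair of numbers: a 1.1-fold higher number from compound 2 to compound 3 (0.04 log units; within the scatter), while a 2.1-fold lower number from compound 1 to compound 3 (0.33 log units; beyond the scatter).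

Compound 4 (`CC(=O)N1N=C(c2ccc3ccccc3c2)OC1c1ccccc1O`) carries 2-hydroxyphenyl in place of 3-fluorophenyl on a saturated ring carbon, keeping the shared core: 2-hydroxyphenyl in place of 3-fluorophenyl on a saturated ring carbon. For the measured compounds named here, the nearest precedent is the 2-bromophenyl group of compound 1, the only measured group numbered like the entering one. The steps leading away from it were modest, a 2.4-fold lower number from compound 1 to compound 2 (0.37 log units; beyond the scatter) and a 2.1-fold lower number from compound 1 to compound 3 (0.33 log units; beyond the scatter). Going by the values given here, no measured compound bears a hydroxy group, so this precedent carries only limited weight.

A shift towards the number of compound 1 is therefore expected in this assay. The expected step is a 1.8-fold higher number from compound 3 to compound 4 (0.26 log units; within the scatter), small and towards a higher number. For compound 4 the estimate is 3.4 ug/mL, with an expected range from 1.3 ug/mL to 8 ug/mL.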

Compound 4, half-maximal inhibitory concentration: 1.84 ug/mL
The estimate for compound 4 lay 1.8-fold (0.27 log units) above the measured number; the measured number falls inside the stated range.
By their numbers in this assay, from the lowest: compounds 2, 4 and 3 (each within the scatter of the next); then compound 1.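

In this assay, 2-hydroxyphenyl on the saturated ring carbon stands level with 3-fluorophenyl (a 1.0-fold lower number from compound 3 to compound 4 (0.00 log units; within the scatter)) and 3-bromophenyl (a 1.1-fold higher number from compound 2 to compound 4 (0.04 log units; within the scatter)), and apart from 2-bromophenyl (a 2.2-fold lower number from compound 1 to compound 4 (0.34 log units; beyond the scatter)). The number of compound 1 therefore does not follow from the 2-substituted name alone: 2-hydroxyphenyl and 2-bromophenyl share that numbering, yet the step between these two groups lies beyond the scatter. The hydrogen-bond donor and acceptor counted for 2-hydroxyphenyl, absent from 3-fluorophenyl, come with no step beyond the scatter from compound 3. No measurement at hand accounts for these numbers.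

As far as these compounds go, whether the number of compound 1 is peculiar to bromo remains open, and 2-chlorophenyl or 2-methoxyphenyl would test that. Also open, from the compounds shown here alone, is how a 3-hydroxyphenyl or 2-aminophenyl group would compare on the shared core.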